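A few compounds are considered here, and "the series" means these few. Any claim that something is new, unique, unknown or untested is made for them only; others in the source may bear on it.

Among the compounds with values here, compound 2 `COc1cc(Cl)cc(-c2nn(-c3cccc(NC(=O)Nc4ccc(Cl)c(C(F)(F)F)c4)c3)cc2-c2ccncc2)c1` is one of two compounds measured in a functional assay on LOX IMVI cells (Homo sapiens) for inhibition, read by sulforhodamine B assay, with a stated time of 48 h, tested at 10 uM; on this read-out lower numbers stand for a stronger effect and higher numbers for a weaker effect at the one concentration tested. In this assay compound 2 gives 4.81%. Within the data shown here, its only measured neighbour is compound 1 `O=C(Nc1cccc(-n2cc(-c3ccncc3)c(-c3cc(O)cc(Cl)c3)n2)c1)Nc1ccc(Cl)c(C(F)(F)F)c1`, which in this assay gives 2.08%; the two differ by a methyl in place of hydrogen on an oxygen on an aromatic ring, and the step of a number 2.7 percentage points higher from compound 1 to compound 2 (within the scatter) lies within the scatter, so the two numbers cannot be told apart. Compound 3 `COc1cc(Cl)cc(-c2nn(-c3cccc(NC(=O)c4cccc(C(F)(F)F)c4)c3)cc2-c2ccncc2)c1` has not yet been measured. It differs from compound 2 by 3-(trifluoromethyl)phenyl in place of (4-chloro-3-(trifluoromethyl)phenyl)amino on a carbonyl carbon, on a carbonyl carbon whose other neighbour is an amide-type nitrogen. Among the measured compounds shown here, no measured step touches this part of the molecule: the one step from compound 1 to compound 2 concerns the oxygen on an aromatic ring and says nothing about the group on the carbonyl carbon. The expectation therefore rests on the structural change alone. Compound 2 sits near the bottom of the scale, leaving little room for a lower number, so the loss of the (4-chloro-3-(trifluoromethyl)phenyl)amino group is expected to move the number upward, by a number 25.2 percentage points higher from compound 2 to compound 3 (beyond the scatter). Compound 3 is thus estimated at 30% in this assay, with a range from 5% to 70%.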

Compound 3, a percentage reported as activity, at one concentration (the size of the read-out at that concentration, not a potency): 51.7%
The estimate for compound 3 lay 21.7 percentage points below the measured number; the range from low to high includes it.
By their numbers in this assay, from the lowest: compounds 1 and 2 (each within the scatter of the next); then compound 3.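

In this assay, the group on the carbonyl carbon proves to be a position where the read-out responds strongly: 3-(trifluoromethyl)phenyl in place of (4-chloro-3-(trifluoromethyl)phenyl)amino gives a number 46.9 percentage points higher from compound 2 to compound 3 (beyond the scatter), whereas the change on the oxygen on an aromatic ring gave only a number 2.7 percentage points higher from compound 1 to compound 2 (within the scatter). This single replacement removes both the chlorine and the amino nitrogen with its hydrogen-bond donor, so the step shows the effect of the whole change and cannot be assigned to either part. Nothing in the data shown explains why the number rises so far.

The compounds shown leave open whether the chlorine or the amino nitrogen matters more, a question that (3-(trifluoromethyl)phenyl)amino and 4-chloro-3-(trifluoromethyl)phenyl on the same carbonyl carbon would address separately. They also leave open whether a methylene in place of that nitrogen would hold the number near that of compound 2, and whether the hydroxyl of compound 1 would give the same result as the methoxy group when paired with 3-(trifluoromethyl)phenyl on the carbonyl carbon.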